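The source may report more compounds than this note shows. Statements on the series, on what has been measured and on what is new or still open speak of the compounds shown alone.

Measured in a functional assay for inhibition, with Homo sapiens as the target; a lower number here means a stronger inhibitor, a higher number a weaker inhibitor:
- compound 1 `CC(C)(C)Sc1c(CC(C)(C)C(=O)O)n(Cc2ccc(Cl)cc2)c2ccc(CCc3ccc4ccccc4n3)cc12`: 4 nM
- compound 2 `CC(C)(C)Sc1c(CC(C)(C)C(=O)O)n(Cc2ccc(Cl)cc2)c2ccc(OCc3nc4ccccc4s3)cc12`: 3 nM
- compound 3 `CC(C)(C)Sc1c(CC(C)(C)C(=O)O)n(Cc2ccc(Cl)cc2)c2ccc(OCc3ccncc3)cc12`: 6 nM

Compound 3 cannot be told apart from the other two, as a 1.5-fold higher number from compound 1 to compound 3 (0.18 log units; within the scatter) and a 2.0-fold higher number from compound 2 to compound 3 (0.30 log units; within the scatter) both lie within the usual scatter.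

Compound 4 `C[C@@H](COc1ccc2c(c1)c(SC(C)(C)C)c(CC(C)(C)C(=O)O)n2Cc1ccc(Cl)cc1)c1ccccn1` keeps the shared core and changes one group: 1-(pyridin-2-yl)ethyl in place of pyridin-4-yl on a saturated chain carbon bound to an oxygen on an aromatic ring. For the measured compounds named here, the entering 1-(pyridin-2-yl)ethyl carries a defined stereocentre, and no measured compound has this group. The nearest evidence is the swap at the same place, a 2.0-fold higher number from compound 2 to compound 3 (0.30 log units; within the scatter), and the wider replacement a 1.3-fold lower number from compound 1 to compound 2 (0.12 log units; within the scatter) is also small. In this assay, no shift beyond the scatter is therefore expected.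

The expected step is no change at the digits printed from compound 3 to compound 4 (within the scatter).

Compound 4 is estimated at 6 nM, with an expected range of 2 nM to 20 nM.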

Compound 4, half-maximal inhibitory concentration: 2 nM
Compound 4: middle estimate off by 3.0-fold (0.48 log units), on the high side, within the range that was stated.
By their numbers in this assay, from the lowest: compounds 4, 2, 1 and 3 (each within the scatter of the next, the first and the last beyond it).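

In this assay, for the compounds shown here, 1-(pyridin-2-yl)ethyl in place of pyridin-4-yl gives a 3.0-fold lower number from compound 3 to compound 4 (0.48 log units; beyond the scatter) and is the only step in this set beyond the scatter, so this position does respond to the group it carries. Compound 4 still cannot be told apart from the two other groups, with a 1.5-fold lower number from compound 2 to compound 4 (0.18 log units; within the scatter) and a 2.0-fold lower number from compound 1 to compound 4 (0.30 log units; within the scatter) both within the scatter. Nothing in the data shown accounts for the step from compound 3.

Going by these compounds, it remains open what a plain pyridin-2-yl or the opposite stereoisomer of 1-(pyridin-2-yl)ethyl would give, and so which part of this change carries the step. Also open, on these data alone, is how a simple amine would behave at this place.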